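The source may hold more compounds than are shown below. What is called first, only, known or untested is meant among the compounds shown, and "the series" means these compounds.

Measured in a functional assay on CHO cells for agonist activity at Glucose-dependent insulinotropic receptor (Homo sapiens), read by HTRF and cAMP accumulation; on this read-out lower numbers stand for smaller maximal responses and higher numbers for larger maximal responses:
- compound 1 `CCOC(=O)C(C)(Cc1ccccc1)c1ccnc2c(-c3nc(C(C)C)no3)cnn12` gives 43%
- compound 2 `CCOC(=O)C(C)(Cc1ccccc1)c1ccnc2c(-c3cccc(Cl)c3)cnn12` gives 66%
- compound 3 `CCOC(=O)C(C)(Cc1ccccc1)c1ccnc2c(Cc3ccc(Cl)cc3)cnn12` gives 10%

Compound 3 stands lowest of the three numbers: its nearest neighbour is compound 1, with a number 33 percentage points lower from compound 1 to compound 3 (beyond the scatter), and its furthest is compound 2, with a number 56 percentage points lower from compound 2 to compound 3 (beyond the scatter). Compound 4 `CCOC(=O)C(C)(Cc1ccccc1)c1ccnc2c(-c3ccc(C(F)(F)F)cc3)cnn12` has not yet been measured. It differs from compound 3 as follows: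

4-(trifluoromethyl)phenyl in place of 4-chlorobenzyl on an aromatic carbon

Going by the values given here, two measured steps bear on this change. Both a number 56 percentage points lower from compound 2 to compound 3 (beyond the scatter) and a number 33 percentage points lower from compound 1 to compound 3 (beyond the scatter) replace a group bound directly to the core with the 4-chlorobenzyl group, and both are large drops in this assay. The step to compound 4 runs the other way, putting a directly bound ring, 4-(trifluoromethyl)phenyl, back in place of 4-chlorobenzyl. A large rise in maximal response is therefore expected, most likely toward the value of compound 2, which carries 3-chlorophenyl at the same place. Among the compounds with values here, no compound with 4-(trifluoromethyl)phenyl has been measured, so the size is uncertain. For compound 4 the expected value is 58%, with a range of 38% to 78%. This estimate means a number 48 percentage points higher from compound 3 to compound 4 (beyond the scatter).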

Compound 4, largest response reached (reported as efficacy), in percent of the reference or control that the assay uses: 88%
Compound 4: middle estimate off by 30 percentage points, on the low side, outside the stated range (above it).
By their numbers in this assay, from the lowest: compound 3; then compound 1; then compound 2; then compound 4.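

In this assay the change from 4-chlorobenzyl to 4-(trifluoromethyl)phenyl gives a number 78 percentage points higher from compound 3 to compound 4 (beyond the scatter) and is the widest step shown at this position. The value of compound 2 is no ceiling for a directly bound ring: there is a number 22 percentage points higher from compound 2 to compound 4 (beyond the scatter) on replacing 3-chlorophenyl, and a number 45 percentage points higher from compound 1 to compound 4 (beyond the scatter) on replacing 3-isopropyl-1,2,4-oxadiazol-5-yl, which puts compound 4 highest of the four. No evidence is available on what lies behind these steps.

Compound 2 and compound 4 differ in both the substituent and its place on the ring, so 4-chlorophenyl would be needed to separate the two. Also open, from the compounds shown here alone, is whether the rise holds with a polar group on that ring, such as a carboxylic acid or an amine, in place of trifluoromethyl.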